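Three Inert Amides and a Thiazole Variant

A few compounds are considered here, and "the series" means these few. Any claim that something is new, unique, unknown or untested is made for them only; others in the source may bear on it.

Compounds measured in an ADME assay on PC-3 cells (Homo sapiens) for cytotoxicity, read by WST assay, tested at 100 uM; on this read-out higher numbers stand for more inhibition at the one concentration tested (going by the name of the read-out) and lower numbers for less inhibition:
compound 1, `O=C(Nc1ccc(Cl)cc1)C1CCCN(C(=O)c2cccc(-c3ccco3)c2)C1`: 0%
compound 2, `CCc1cccc(NC(=O)C2CCCN(C(=O)c3cc(C(F)(F)F)cc(C(F)(F)F)c3)C2)c1`: 0%
compound 3, `O=C(Nc1cccc(Cc2ccccc2)c1)C1CCCN(C(=O)c2cc(C(F)(F)F)cc(C(F)(F)F)c2)C1`: 0%

Compound 1 stands level with compound 2 and compound 3 at the digits shown; all three give no measurable inhibition in this assay. Among the compounds with values here, the only single-point comparison available, no change at the digits printed from compound 2 to compound 3 (within the scatter), shows that a large change on the anilide side left the read-out unmoved.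

Compound 4, `Cc1nc(-c2cccc(C(=O)N3CCCC(C(=O)Nc4ccc(Cl)cc4)C3)c2)cs1`, has not yet been measured. It differs from compound 1 by 2-methyl-1,3-thiazol-4-yl in place of furan-2-yl on an aromatic carbon, on the acyl side of the shared core rather than the anilide side. Within the data shown here, no measured step touches this position, so the expectation rests on the flat picture across compounds 1 to 3: every compound so far sits at the bottom of the scale, and a change of this size is not expected to move it beyond the scatter. Compound 4 is therefore expected to give 0%, within a range of -8% to 10%. For compound 4 the expected step is no change at the digits printed from compound 1 to compound 4 (within the scatter), that is, none beyond the scatter.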

Compound 4, a percentage reported as inhibition, at one concentration (the size of the read-out at that concentration, not a potency): 1%
Compound 4: middle estimate off by 1 percentage points, on the low side; the measured number falls inside the stated range.
By their numbers in this assay, from the lowest: compounds 1, 2, 3 and 4 (each within the scatter of the next).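

On the acyl side of the shared core, 2-methyl-1,3-thiazol-4-yl in place of furan-2-yl gives a number 1 percentage points higher from compound 1 to compound 4 (within the scatter) in this assay and so leaves the read-out flat. The earlier step touched only the anilide side, whereas this one shows the same flat read-out with a change of ring on this aromatic carbon. Nothing available explains this flat result.

As far as these compounds go, whether a carboxylic acid or an amine on this aromatic carbon would lift the read-out stays open. The compounds shown also leave open which change, on either side of the shared core, could move it beyond the scatter.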